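Ethyl on the Sulfonamide Nitrogen of Compound 2

This account rests on a few compounds, and the source may have more. Where it says the series, first, only, none or still open, it means among the compounds named here.

Compound 1 `CS(=O)(=O)NNc1nonc1/C(=N/O)Nc1ccc(F)c(Br)c1`: 609 nM
Compound 2 `NS(=O)(=O)CCNc1nonc1/C(=N/O)Nc1ccc(F)c(Br)c1`: 71 nM

In an assay on isolated protein for inhibition of Indoleamine 2,3-dioxygenase 1 (Homo sapiens), read by fluorescence, with a stated time of 60 min (on this read-out lower numbers stand for stronger inhibition and higher numbers for weaker inhibition), compound 2 gives 71 nM, the lower of the two measured numbers; the step of an 8.6-fold lower number from compound 1 to compound 2 (0.93 log units; beyond the scatter) separates it from compound 1. Compound 3 `CCNS(=O)(=O)CCNc1nonc1/C(=N/O)Nc1ccc(F)c(Br)c1` differs from compound 2 by ethyl in place of hydrogen on a sulfonamide nitrogen. Within the data shown here, no measured step touches this nitrogen, since the one step known changes the linker, not its substitution, so no direction is indicated. Compound 3 is estimated at 100 nM, with a range of 35 nM to 300 nM. The expected step is a 1.4-fold higher number from compound 2 to compound 3 (0.15 log units; within the scatter), within the scatter.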

Compound 3, half-maximal inhibitory concentration: 95 nM
The estimate for compound 3 lay 1.1-fold (0.02 log units) above the measured number; the measured number falls inside the stated range.
By their numbers in this assay, from the lowest: compounds 2 and 3 (each within the scatter of the next); then compound 1.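

In this assay, ethyl on the sulfonamide nitrogen gives a 1.3-fold higher number from compound 2 to compound 3 (0.13 log units; within the scatter), so a free sulfamoyl group is not required for the number seen with compound 2. The ethylsulfamoyl compound also stays clear of the methanesulfonamido compound, with a 6.4-fold lower number from compound 1 to compound 3 (0.81 log units; beyond the scatter). No available evidence explains this result. From the compounds shown here alone, whether a longer chain, a cyclopropyl ring or a second ethyl on this nitrogen would leave the number unchanged remains open.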